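The compounds below may be only part of what the source reports. "The series", "measured", "known", "first", "only" and "open" are said of these compounds alone.

Compound 1 `COc1ccc2c(=O)c(/C=C/C(=O)NCc3ccccc3)coc2c1` carries a benzyl group on its amide nitrogen. In a functional assay on Huh-7 cells (Homo sapiens) for inhibition, read by MTT assay, with a stated time of 48 h (a higher number here means a weaker inhibitor, a lower number a stronger inhibitor), compound 1 gives 13600 nM. Compound 2 `COc1ccc2c(=O)c(/C=C/C(=O)Nc3ccc(C)cc3)coc2c1` has a 4-methylphenyl in that place. In this assay compound 2 gives > 100000 nM, which is a limit of the assay rather than a number (the limit of > 100000 nM in this assay, at which 1 of the 2 values shown sits). The step of an at least 7.3-fold higher number from compound 1 to compound 2 (0.86 log units; beyond the scatter) is therefore at least modest, and compound 2 stands at the weak end of what has been measured. Compound 3 `CCOc1ccc(NC(=O)/C=C/c2coc3cc(OC)ccc3c2=O)cc1` keeps the amide-linked aromatic ring of compound 2 and changes only the group on it: ethoxy in place of methyl on an aromatic carbon. Among the compounds with values here, no measured step covers this change; the one known step, from benzyl to 4-methylphenyl, alters the link between nitrogen and ring rather than the group on the ring, so it gives no direction for the exchange of methyl for ethoxy. Since compound 2 already sits at the limit, compound 3 is expected to remain near it, with the expected step of a number no higher from compound 2 to compound 3 (the limit leaves the size open) not beyond the scatter. Compound 3 is estimated at 100000 nM, within 20000 nM to 400000 nM.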

Compound 3, half-maximal inhibitory concentration: 3230 nM
Compound 3: middle estimate off by 31-fold (1.49 log units), on the high side; the measured number lies below the stated range.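

In this assay, the group on this aromatic ring matters a great deal: ethoxy in place of methyl gives an at least 30-fold lower number from compound 2 to compound 3 (1.49 log units; beyond the scatter), so the ring attached directly to the amide nitrogen does not by itself bring the weak result of compound 2. This also changes how the earlier step from benzyl to 4-methylphenyl reads, since 4-ethoxyphenyl in place of benzyl gives a 4.2-fold lower number from compound 1 to compound 3 (0.62 log units; beyond the scatter), and a directly attached aromatic ring can therefore go with a stronger result than the benzyl group as well as a weaker one. The full size of the change from methyl to ethoxy remains unknown because compound 2 sits at a limit of the assay, so its step has only a lower bound: the limit of > 100000 nM in this assay, at which 1 of the 3 values shown sits.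

The compounds shown do not separate the oxygen of the ethoxy group from its greater length, and a propyl chain or a methoxy group in the same place would help tell these two apart. They also leave open how an amine or a carboxylic acid on this ring would read in this assay, and whether ethoxy on the benzyl ring of compound 1 would bring a similar shift.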